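Changing the Amide Side Chain of Compound 2

This account rests on a few compounds, and the source may have more. Where it says the series, first, only, none or still open, it means among the compounds named here.

In an ADME assay on microsomes from liver (Rattus norvegicus) for metabolic stability, read by mass spectrometry, with a stated time of 10 min, tested at 0.5 uM (on this read-out higher numbers stand for a more stable compound and lower numbers for a less stable compound), compound 1 `CNc1cc(Nc2cc(C)cc(C)c2)nn2c(C(N)=O)cnc12` gives 21% while compound 2 `CNc1cc(Nc2cc(C)cc(C)c2)nn2c(C(=O)NCC(C)(CO)CO)cnc12` gives 16% and compound 3 `CNc1cc(Nc2cccc(C(C)(C)C)c2)nn2c(C(N)=O)cnc12` gives 4% on the same read-out. Compound 2 thus stands level with compound 1 within the scatter and clearly above compound 3. The change to compound 4 `CNc1cc(Nc2cc(C)cc(C)c2)nn2c(C(=O)NC3CC3)cnc12` is cyclopropyl in place of 2,2-bis(hydroxymethyl)propyl on an amide-type nitrogen and it puts cyclopropyl in place of 2,2-bis(hydroxymethyl)propyl on an amide-type nitrogen. Among the measured compounds shown here, only one measured step touches this nitrogen, and a number 5 percentage points lower from compound 1 to compound 2 (within the scatter) lies within the scatter, so no step beyond the scatter is expected in this assay here. The expected step is a number 1 percentage points lower from compound 2 to compound 4 (within the scatter) and stays within the scatter. For compound 4 the estimate is 15% with an expected range from 6% to 28% in repeat measurements.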

Compound 4, percent of the compound remaining: 14%
The estimate for compound 4 lay 1 percentage points above the measured number, within the range that was stated.
By their numbers in this assay, from the lowest: compounds 3, 4, 2 and 1 (each within the scatter of the next, the first and the last beyond it).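

In this assay, cyclopropyl in place of 2,2-bis(hydroxymethyl)propyl gives a number 2 percentage points lower from compound 2 to compound 4 (within the scatter) on the amide-type nitrogen, and cyclopropyl in place of hydrogen gives a number 7 percentage points lower from compound 1 to compound 4 (within the scatter) there. So a ring without hydrogen-bond donors now joins the open chain with two of them and plain hydrogen, and all three read alike within the scatter at this nitrogen. No measurement explaining this is on hand. As far as these compounds go, whether a chain ending in an amine or a carboxylic acid would read the same stays open, as does a longer plain alkyl chain.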